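A few compounds are considered here, and "the series" means these few. Any claim that something is new, unique, unknown or untested is made for them only; others in the source may bear on it.

Series notes. Compound 1 `CN(C)CCCNc1nc(-c2ccc(NC(=O)Nc3ccc(Cl)cc3)cc2)nc2c(Cl)c(Cl)sc12` in a functional assay on MDA-MB-231 cells (Homo sapiens) for cytotoxicity, read by MTT assay, with a stated time of 72 h (a higher number here means a weaker inhibitor, a lower number a stronger inhibitor), gives 1160 nM. Compound 2 `CN(C)CCCNc1nc(-c2ccc(NC(=O)Nc3ccccc3Cl)cc2)nc2c(Cl)c(Cl)sc12` gives 1560 nM; the change is 2-chlorophenyl in place of 4-chlorophenyl on an amide-type nitrogen, and the step is a 1.3-fold higher number from compound 1 to compound 2 (0.13 log units; within the scatter). Compound 3 `CN(C)CCNc1nc(-c2ccc(NC(=O)Nc3ccc(Cl)cc3)cc2)nc2c(Cl)c(Cl)sc12` gives 870 nM; its core differs from that of compound 1 by dimethylamino in place of (dimethylamino)methyl on a saturated chain carbon, two bonds along the chain from a nitrogen on an aromatic ring, a step of a 1.3-fold lower number from compound 1 to compound 3 (0.12 log units; within the scatter).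

Compound 4 `CN(C)CCNc1nc(-c2ccc(NC(=O)Nc3ccccc3Cl)cc2)nc2c(Cl)c(Cl)sc12` is not yet measured in this assay. It differs from compound 3 by 2-chlorophenyl in place of 4-chlorophenyl on an amide-type nitrogen; the place is the same word for word as in the change from compound 1 to compound 2, so this is the same change made on the core of compound 3. The step is expected to be a 1.3-fold higher number from compound 3 to compound 4 (0.12 log units; within the scatter) because a 1.3-fold higher number from compound 1 to compound 2 (0.13 log units; within the scatter) was within the scatter. Compound 4 is estimated at 1150 nM, expected between 600 nM and 2200 nM.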

Compound 4, half-maximal inhibitory concentration: 1350 nM
Estimate against measurement, compound 4: 1.2-fold (0.07 log units) below, and the stated range covers the measured number.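

In this assay, 2-chlorophenyl in place of 4-chlorophenyl on an amide-type nitrogen gives a 1.6-fold higher number from compound 3 to compound 4 (0.19 log units; within the scatter), and the change reads alike on the two cores: the same change on two cores in this assay, a 1.3-fold higher number (0.13 log units; within the scatter) from compound 1 to compound 2 and a 1.6-fold higher number (0.19 log units; within the scatter) from compound 3 to compound 4, 1.2-fold (0.06 log units) apart, within the scatter of two such steps

Dimethylamino in place of (dimethylamino)methyl gives a 1.2-fold lower number from compound 2 to compound 4 (0.06 log units; within the scatter), and this change also reads alike on the two cores: the same change on two cores in this assay, a 1.3-fold lower number (0.12 log units; within the scatter) from compound 1 to compound 3 and a 1.2-fold lower number (0.06 log units; within the scatter) from compound 2 to compound 4, 1.2-fold (0.06 log units) apart, within the scatter of two such steps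

Among the compounds shown here, every one of these steps lies within the scatter, so the agreement shows only that neither change separates these compounds on either core, not that a real effect carries from one core to another.

Still open, from the compounds shown here alone, is whether the same holds for other groups on the amide-type nitrogen, such as phenyl or 4-methoxyphenyl. Also open, going by these compounds, is the effect of a cyclic amine such as morpholine in place of dimethylamino.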